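This account rests on a few compounds, and the source may have more. Where it says the series, first, only, none or still open, it means among the compounds named here.

Measured compounds: compound 1 `CC(C)c1onc(-c2c(Cl)cccc2Cl)c1COc1ccc(-c2nc3ccc(C(=O)O)cc3n2CC2CCCCC2)c(F)c1`, "not determined" (no result reported) in an assay on isolated protein for agonist activity at Bile acid receptor (Homo sapiens), read by TR-FRET; a lower number here means that less compound is needed, a higher number that more compound is needed for the effect; compound 2 `CC(C)c1onc(-c2c(Cl)cccc2Cl)c1COc1ccc(-c2nc3ccc(C(=O)O)cc3n2CC(C)(C)C)cc1`, 24.8 nM; compound 3 `CC(C)c1onc(-c2c(Cl)cccc2Cl)c1COc1ccc(-c2nc3ccc(C(=O)O)cc3n2C2CC2)cc1`, 117 nM.

Compound 2 holds the lowest of the two numbers in this assay; compound 1 carries no number at all. For the measured compounds named here, the only measured step at this position is a 4.7-fold higher number from compound 2 to compound 3 (0.67 log units; beyond the scatter). Compound 4 `CC(C)c1onc(-c2c(Cl)cccc2Cl)c1COc1ccc(-c2nc3ccc(C(=O)O)cc3n2C2CCCCCC2)cc1` differs from compound 2 by cycloheptyl in place of neopentyl on an aromatic nitrogen. Going by these compounds, that change swaps the neopentyl for a larger ring rather than a smaller one, so the step to compound 3 bears on it only loosely, and the direction for compound 4 remains open. A step of modest size at most is expected, leaning toward a higher number. Compound 4 is expected to give 40 nM (range 12 nM to 130 nM), an estimated step of a 1.6-fold higher number from compound 2 to compound 4 (0.21 log units; within the scatter).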

Compound 4, half-maximal effective concentration: 113 nM
Compound 4: middle estimate off by 2.8-fold (0.45 log units), on the low side; the measured number falls inside the stated range.
By their numbers in this assay, from the lowest: compound 2; then compounds 4 and 3 (each within the scatter of the next).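

In this assay, the two ring compounds on the aromatic nitrogen are not separated despite their different ring sizes: cycloheptyl in place of cyclopropyl gives a 1.0-fold lower number from compound 3 to compound 4 (0.02 log units; within the scatter). Cycloheptyl in place of neopentyl gives a 4.6-fold higher number from compound 2 to compound 4 (0.66 log units; beyond the scatter), so among these three compounds, the open-chain neopentyl alone stands apart, whichever ring replaces it. No measured evidence accounts for this.

Open, going by these compounds, is whether another open chain, such as isobutyl or a longer chain, would match compound 2. Also open, on these data alone, is whether a ring holding an oxygen, such as tetrahydropyranyl, would behave like the carbon-only rings.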